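Trifluoromethyl in place of phenyl: notes on a small series

The compounds below may be only part of what the source reports. "The series", "measured", "known", "first", "only" and "open" are said of these compounds alone.

Measured so far in a functional assay on NCI/ADR-RES cells (Homo sapiens) for inhibition, read by sulforhodamine B assay, with a stated time of 48 h, tested at 10 uM; a lower number here means less inhibition of growth, a higher number more inhibition of growth at the concentration tested:
compound 1 `CCOC(=O)c1ccc(Nc2ccnc(SCC(=O)c3ccc([N+](=O)[O-])cc3)n2)cc1` gives 27% as read
compound 2 `CC(=O)c1cccc(Nc2ccnc(SCC(=O)c3ccc(-c4ccccc4)cc3)n2)c1` gives 14% as read

Compound 2 (14%) is the lower of the two values, and its gap to compound 1 (27%) lies beyond the scatter. These two compounds differ in more than one place, so their gap cannot be assigned to any single group.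

Compound 3 `CC(=O)c1cccc(Nc2ccnc(SCC(=O)c3ccc(C(F)(F)F)cc3)n2)c1` keeps the shared core of compound 2 and carries trifluoromethyl in place of phenyl on an aromatic carbon, para to a large group (trifluoromethyl in place of phenyl on an aromatic carbon). Within the data shown here, no measured pair isolates this change, which leaves compound 2 (14%) as the closest anchor for an expectation. The expected change is small, with a slight rise at most and nothing expected beyond the scatter in this assay, and the estimated step is a number 3 percentage points higher from compound 2 to compound 3 (within the scatter) as the working figure. Compound 3 is estimated at 17% (expected range 4% to 32%).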

Compound 3, percent growth inhibition at one concentration: 11%
Estimate against measurement, compound 3: 6 percentage points above; low and high end bracket the measured number.
By their numbers in this assay, from the lowest: compounds 3 and 2 (each within the scatter of the next); then compound 1.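

Among these compounds, this is the first pair that differs in one place, and it gives a readable step in this assay: a number 3 percentage points lower from compound 2 to compound 3 (within the scatter). On this aromatic carbon, para to a large group, a phenyl of 6 heavy atoms with its six-membered aromatic ring can therefore give way to a trifluoromethyl of 4 heavy atoms and no ring without a change that can be told from the scatter, with compound 2 at 14% and compound 3 at 11%. Nothing available bears on why the two readings stay within the scatter of each other.

This single swap says nothing about whether the position is insensitive in general, and an amine or a carboxylic acid at the same carbon would test that more sharply than a second uncharged group with no hydrogen-bond donors or acceptors. Among the compounds shown here, the gap between compound 1 at 27% and compound 2 at 14% also stays unassigned, as those two compounds differ in more than one place and no single-change pair yet separates their contributions.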